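Replacing a benzyloxy arm with a directly attached aryl

This account rests on a few compounds, and the source may have more. Where it says the series, first, only, none or still open, it means among the compounds named here.

Compound 1 `Cc1nn(-c2ncnc3nc[nH]c23)c2c1C(OCc1ccc(Cl)cc1Cl)CC(=O)N2`: 243 nM
Compound 2 `Cc1nn(-c2ncnc3nc[nH]c23)c2c1C(OCc1ccc(F)cc1)CC(=O)N2`: 126 nM
Compound 3 `Cc1nn(-c2ncnc3nc[nH]c23)c2c1C(OCc1ccccc1Cl)CC(=O)N2`: 47 nM

In a functional assay on HEK293 cells for agonist activity at G-protein coupled receptor 39 (Homo sapiens), read by scintillation proximity assay and inositol phosphate accumulation, with a stated time of 75 min (a lower number here means that less compound is needed, a higher number that more compound is needed for the effect), compound 1 gives the highest of these three numbers. Compound 2 sits within the scatter of it (a 1.9-fold lower number from compound 1 to compound 2 (0.29 log units; within the scatter)), whereas compound 3 lies clearly lower (a 5.2-fold lower number from compound 1 to compound 3 (0.71 log units; beyond the scatter)), as does the step of a 2.7-fold lower number from compound 2 to compound 3 (0.43 log units; beyond the scatter). Compound 4 `Cc1nn(-c2ncnc3nc[nH]c23)c2c1C(c1ccc(F)cc1Cl)CC(=O)N2` differs from compound 1 by 2-chloro-4-fluorophenyl in place of (2,4-dichlorobenzyl)oxy on a saturated ring carbon. The measured steps concern only the halogen pattern on the aromatic ring and were modest; none shows what happens when the oxygen and the saturated chain carbon are removed. The step from compound 1 to compound 4 is therefore expected to stay within the scatter, a 1.2-fold lower number from compound 1 to compound 4 (0.08 log units; within the scatter), with wide uncertainty. Compound 4 is estimated at 200 nM, ranging from 40 nM to 1000 nM.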

Compound 4, half-maximal effective concentration: 280 nM
The estimate for compound 4 lay 1.4-fold (0.15 log units) below the measured number; the range from low to high includes it.
By their numbers in this assay, from the lowest: compound 3; then compounds 2, 1 and 4 (each within the scatter of the next, the first and the last beyond it).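

Shortening the arm need not change the number: with 2-chloro-4-fluorophenyl directly on the saturated ring carbon, the result is a 1.2-fold higher number from compound 1 to compound 4 (0.06 log units; within the scatter) and so matches the dichlorinated benzyloxy arm. The outcome depends on the arm it replaces, with a 2.2-fold higher number from compound 2 to compound 4 (0.35 log units; beyond the scatter) and a 6.0-fold higher number from compound 3 to compound 4 (0.78 log units; beyond the scatter) showing that the direct aryl falls short of those two arms, though the halogens change in these steps too. Nothing available explains these differences.

Still open, as far as these compounds go, is whether a directly attached 2-chlorophenyl would reach the level of compound 3. Also open, from the compounds shown here alone, is how a longer chain, such as a two-carbon link to the aryl, or an amine at this carbon would behave.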